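A few compounds are considered here, and "the series" means these few. Any claim that something is new, unique, unknown or untested is made for them only; others in the source may bear on it.

Measured so far in a functional assay on HepG2 cells (Homo sapiens) for cytotoxicity, read by MTT assay, with a stated time of 48 h; a higher number here means a weaker inhibitor, a lower number a stronger inhibitor:
compound 1 `CCN(CC)CC(=O)N1N=C(C)CC1c1ccccc1O` gives 51600 nM;
compound 2 `CC1=NN(C(=O)CN2CCC(c3ccccc3)CC2)C(c2ccccc2O)C1` gives 23300 nM;
compound 3 `O=C(c1ccccc1Cl)N1N=C(c2cc3ccccc3oc2=O)CC1c1ccccc1` gives 5440 nM.

Of these three, compound 3 has the lowest number in this assay, and its gaps to compound 2 and to compound 1 both lie beyond the usual scatter, so compound 3 is the strongest of the three measured. Compound 4 `CC1CCCN(CC(=O)N2N=C(c3cc4ccccc4oc3=O)CC2c2ccccc2)C1` is compound 3 with a single change: (3-methylpiperidin-1-yl)methyl in place of 2-chlorophenyl on a carbonyl carbon. Within the data shown here, no pair of measured compounds differs in just this place, so the step has no direct precedent. Compound 1 and compound 2 each carry a nitrogen-containing chain on the same carbonyl and each gives a higher number than compound 3, but both also differ from compound 3 in the shared core, so their values are only a loose hint. For compound 4 a shift toward a higher number is expected, modest but probably beyond the scatter, as the expected step of a 2.6-fold higher number from compound 3 to compound 4 (0.41 log units; beyond the scatter) shows. Compound 4 is accordingly estimated to give 14000 nM, with a likely range from 4500 nM to 45000 nM.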

Compound 4, half-maximal inhibitory concentration: "not active" (no number reported)
For compound 4 the study gives words and no number; the estimate stays without a comparison.
By their numbers in this assay, from the lowest: compound 3; then compound 2; then compound 1.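

In this assay, among these compounds, compound 4 is reported only as "not active", with no number, so no step from compound 3 to compound 4 can be read. The compounds shown leave open how large a shift this single change causes, and no available evidence accounts for the result.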